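Ketone-side aryl swap in the shared core series

The compounds below may be only part of what the source reports. "The series", "measured", "known", "first", "only" and "open" are said of these compounds alone.

Measured compounds:
compound 1: `O=C(/C=C/c1cn(-c2ccccc2)nc1-c1cccnc1)c1ccsc1` — 1300 nM
compound 2: `COc1cc(OC)c(C(=O)/C=C/c2cn(-c3ccccc3)nc2-c2cccnc2)c(OC)c1` — 300 nM

Both were run in a functional assay on HCT-116 cells (Homo sapiens) for inhibition, read by sulforhodamine B assay, with a stated time of 72 h; a lower number here means a stronger inhibitor, a higher number a weaker inhibitor. Compound 1 stands highest of the two numbers there; the nearest, compound 2, gives 300 nM, and that gap lies beyond the scatter. Among the compounds with values here, no step between measured compounds that differ in a single place is available, so the effect of any one change remains to be seen.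

Compound 3, `COc1ccc(C(=O)/C=C/c2cn(-c3ccccc3)nc2-c2cccnc2)cc1OC`, differs from compound 1 by 3,4-dimethoxyphenyl in place of thiophen-3-yl on a carbonyl carbon. The step from compound 1 to compound 3 is expected to be downward, beyond the scatter, because compound 2 with its methoxy-bearing six-membered ring on the carbonyl carbon gives 300 nM while compound 1 gives 1300 nM. The expected step is a 3.3-fold lower number from compound 1 to compound 3 (0.51 log units; beyond the scatter). For compound 3 the estimate in this assay is 400 nM, with a range from 150 nM to 1200 nM.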

Compound 3, half-maximal inhibitory concentration: 4300 nM
Compound 3: middle estimate off by 11-fold (1.03 log units), on the low side; measured number above the stated range.
By their numbers in this assay, from the lowest: compound 2; then compound 1; then compound 3.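

In this assay, 3,4-dimethoxyphenyl in place of thiophen-3-yl on the carbonyl carbon gives a 3.3-fold higher number from compound 1 to compound 3 (0.52 log units; beyond the scatter), so a methoxy-bearing six-membered ring at this position does not by itself give a lower number. The printed values separate the two methoxy-bearing compounds: compound 2 gives 300 nM and compound 3 gives 4300 nM, with only the ring on the carbonyl carbon differing, so the outcome depends on more than the presence of methoxy groups. Nothing on hand bears on what lies behind the higher number of compound 3.

Still open, from the compounds shown here alone, is how far the number at this position follows the pattern of substitution on the six-membered ring. The compounds shown also leave open what an amine or a carboxylic acid on that ring would give.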